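Working notes: the step to compound 3

This account rests on a few compounds, and the source may have more. Where it says the series, first, only, none or still open, it means among the compounds named here.

In a functional assay on FL5.12 cells (Mus musculus) for cytotoxicity, read by flow cytometry and propidium iodide staining, with a stated time of 48 h (a higher number here means a weaker inhibitor, a lower number a stronger inhibitor), compound 1 `CCCCCCCCc1ccc(C(=O)C[C@@H]2C[C@@H](O)CN2)cc1` gives 2100 nM and compound 2 `CCCCCCCCc1ccc(C(=O)CC[C@H]2C[C@H](CO)CN2)cc1` gives 4000 nM. Among the measured compounds shown here, compound 2 therefore stands within the scatter of compound 1, the only other measured compound. Compound 3 `CCCCCCCCc1ccc(C(=O)CC[C@@H]2C[C@@H](O)CN2)cc1` differs from compound 2 by a group of 6 heavy atoms (4 carbon, 1 nitrogen, 1 oxygen; one five-membered non-aromatic ring with 1 hetero atom) in place of a group of 7 heavy atoms (5 carbon, 1 nitrogen, 1 oxygen; one five-membered non-aromatic ring with 1 hetero atom), on a saturated chain carbon, two bonds along the chain from a carbonyl carbon: 4-hydroxypyrrolidin-2-yl enters on a saturated chain carbon, two bonds along the chain from a carbonyl carbon. For the measured compounds named here, the only measured step bearing on this change is a 1.9-fold higher number from compound 1 to compound 2 (0.28 log units; within the scatter). That step also alters a group with one five-membered non-aromatic ring and stays within the scatter. No step beyond the scatter is therefore expected in this assay. The expected result is a 1.3-fold lower number from compound 2 to compound 3 (0.12 log units; within the scatter), which remains within the scatter. Compound 3 is estimated at 3000 nM, with an expected range of 1500 nM to 6000 nM.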

Compound 3, half-maximal inhibitory concentration: 2100 nM
For compound 3 the middle estimate is 1.4-fold (0.15 log units) above the measured one, and the stated range covers the measured number.
By their numbers in this assay, from the lowest: compounds 1, 3 and 2 (each within the scatter of the next).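

In this assay, 4-hydroxypyrrolidin-2-yl on a saturated chain carbon, two bonds along the chain from a carbonyl carbon, gives a 1.9-fold lower number from compound 2 to compound 3 (0.28 log units; within the scatter) and adds a second exchange at this place that stays inside the scatter. Set against compound 1, (4-hydroxypyrrolidin-2-yl)methyl in place of 4-hydroxypyrrolidin-2-yl on a saturated chain carbon bound to a carbonyl carbon gives no change at the digits printed from compound 1 to compound 3 (within the scatter) as the series' closest pair so far, so all three listed exchanges remain inside the scatter. Nothing available accounts for these steps. The compounds shown leave open whether a carboxylic acid or an amine in place of 4-hydroxypyrrolidin-2-yl at this place would give a step beyond the scatter. They also leave open how a longer chain carrying the same group would read.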